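Permeability series: oxazole isomer swap at the sulfonamide aryl

A few compounds are considered here, and "the series" means these few. Any claim that something is new, unique, unknown or untested is made for them only; others in the source may bear on it.

Measured so far:
Compound 1 `Cc1noc(CNC(=O)c2ccc(C)c(S(=O)(=O)Nc3ccc(Cl)cc3)c2)n1`: 19 10^-6 cm/s
Compound 2 `Cc1ccc(NS(=O)(=O)c2cc(C(=O)NCc3nc(C)no3)ccc2C)cc1`: 20 10^-6 cm/s
Compound 3 `Cc1noc(CNC(=O)c2ccc(C)c(S(=O)(=O)Nc3ccc(-c4ccno4)cc3)c2)n1`: 6 10^-6 cm/s

All three were run in an ADME assay on MDCK-II cells (Canis lupus familiaris) for permeability; on this read-out lower numbers stand for lower permeability and higher numbers for higher permeability. Compound 3 gives the lowest number of the three; the steps of a 3.2-fold lower number from compound 1 to compound 3 (0.50 log units; beyond the scatter) and a 3.3-fold lower number from compound 2 to compound 3 (0.52 log units; beyond the scatter) both lie beyond the scatter, while a 1.1-fold higher number from compound 1 to compound 2 (0.02 log units; within the scatter) does not.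

Compound 4 `Cc1noc(CNC(=O)c2ccc(C)c(S(=O)(=O)Nc3ccc(-c4cnco4)cc3)c2)n1` differs from compound 3 by 1,3-oxazol-5-yl in place of 1,2-oxazol-5-yl on an aromatic carbon. Among the measured compounds shown here, no measured step swaps one five-membered ring for another; the two steps that bear on this position only show what the 1,2-oxazol-5-yl did against chloro or methyl. With the same atoms joined differently, no step beyond the scatter is expected in this assay, so compound 4 is estimated at 6 10^-6 cm/s, range 3 10^-6 cm/s to 13 10^-6 cm/s, a step of no change at the digits printed from compound 3 to compound 4 (within the scatter).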

Compound 4, apparent permeability: 10 10^-6 cm/s
Compound 4: the middle estimate sits 1.7-fold (0.22 log units) below what was measured; the measured number falls inside the stated range.
By their numbers in this assay, from the lowest: compounds 3, 4, 1 and 2 (each within the scatter of the next, the first and the last beyond it).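

In this assay, moving from 1,2-oxazol-5-yl to 1,3-oxazol-5-yl on this aromatic carbon stays within the scatter (a 1.7-fold higher number from compound 3 to compound 4 (0.22 log units; within the scatter)). Unlike the 1,2-oxazol-5-yl, the 1,3-oxazol-5-yl also stays within the scatter of methyl (a 2.0-fold lower number from compound 2 to compound 4 (0.30 log units; within the scatter)) and chloro (a 1.9-fold lower number from compound 1 to compound 4 (0.28 log units; within the scatter)), so at this position the two ring isomers differ in how they read against the smaller groups, though not against each other. No measurement here speaks to the cause of these steps.

As far as these compounds go, how an amine or a carboxylic acid on this same aromatic carbon would read against the oxazoles, chloro and methyl remains open.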